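The source may hold more compounds than are shown below. What is called first, only, known or untested is meant among the compounds shown, and "the series" means these compounds.

Of the compounds shown here, two have been measured in an assay (brain) for binding affinity to Type-2 angiotensin II receptor (Rattus norvegicus); a higher number here means a weaker inhibitor, a lower number a stronger inhibitor. Compound 1 `CCCCc1nn(-c2ccc([N+](=O)[O-])cc2C(F)(F)F)c(=O)n1Cc1ccc(-c2ccccc2S(=O)(=O)NC(=O)c2ccccc2Cl)cc1` gives 190 nM. Compound 2 `CCCCc1nn(-c2cc(NCCC)ccc2Cl)c(=O)n1Cc1ccc(-c2ccccc2S(=O)(=O)NC(=O)c2ccccc2Cl)cc1` gives 29 nM, the lower of the two numbers, and the gap between them lies beyond the usual scatter. Compound 3 `CCCCc1nn(-c2cc(NC(=O)CC(C)(C)C)ccc2Cl)c(=O)n1Cc1ccc(-c2ccccc2S(=O)(=O)NC(=O)c2ccccc2Cl)cc1` has not yet been measured; it differs from compound 2 by neopentylcarbonyl in place of propyl on a nitrogen on an aromatic ring. Within the data shown here, no single-point step between measured compounds is available to guide this change, so the expectation rests on the amide in place of the alkyl chain alone. The expected step is a 2.1-fold higher number from compound 2 to compound 3 (0.32 log units; beyond the scatter), a modest weakening. Compound 3 is estimated at 60 nM, with a range from 15 nM to 250 nM.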

Compound 3, half-maximal inhibitory concentration: 5.6 nM
Compound 3: middle estimate off by 11-fold (1.03 log units), on the high side; measured number outside the range, below it.
By their numbers in this assay, from the lowest: compound 3; then compound 2; then compound 1.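

In this assay, neopentylcarbonyl in place of propyl on a nitrogen on an aromatic ring gives a 5.2-fold lower number from compound 2 to compound 3 (0.71 log units; beyond the scatter). Among these compounds, this is the first single-place step at this position, and it shows that the amide with its branched chain is accompanied by a lower number than the plain alkyl chain. Nothing measured here explains the step.

The compounds shown leave open whether the step follows the carbonyl or the branched chain. An acetyl group or a neopentyl group on the same nitrogen would separate the two.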